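Vinyl in place of 2-carboxyethenyl at the assay limit

The source may hold more compounds than are shown below. What is called first, only, known or untested is meant among the compounds shown, and "the series" means these compounds.

In a functional assay on WiDr cells (Homo sapiens) for antiproliferative activity, read by sulforhodamine B assay, with a stated time of 48 h (on this read-out lower numbers stand for stronger inhibition of growth and higher numbers for weaker inhibition of growth), compound 1 `COC(=O)/C=C/[C@H]1OCCC[C@H]1O[Si](C)(C)C(C)(C)C` gives > 100000 nM as a limit of the assay. Compound 2 `CC(C)(C)[Si](C)(C)O[C@@H]1CCCO[C@@H]1/C=C/C(=O)O` gives > 100000 nM and this too is a limit of the assay. Compound 2 stands only at the limit of > 100000 nM in this assay, at which 2 of the 2 values shown sit, without a number of its own. For the measured compounds named here, the one measured step is a step that the two limits leave unreadable from compound 1 to compound 2 and it gives no size to carry over. Compound 3 `C=C[C@H]1OCCC[C@H]1O[Si](C)(C)C(C)(C)C` differs from compound 2 by vinyl in place of 2-carboxyethenyl on a saturated ring carbon in one change, vinyl in place of 2-carboxyethenyl on a saturated ring carbon. Going by the values given here, no measured step touches that place. The expectation therefore rests on compound 2 with its limit of > 100000 nM as the only anchor. The estimated change a number no higher from compound 2 to compound 3 (the limit leaves the size open) in this assay is expected to stay within the scatter, with no direction claimed. For compound 3 the estimated value is 100000 nM with an expected range from 30000 nM to 200000 nM and a report as a limit is likely.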

Compound 3, concentration for 50% growth inhibition: > 100000 nM
Compound 3: a limit, no number; the forecaster's own chance of this, stated with the estimate: 85%; the middle value lies on the limit itself.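

For the compounds shown here, no step among compound 1, compound 2 and compound 3 can be read, because all three stand at a limit of the assay and not at a number: the limit of > 100000 nM in this assay, at which 3 of the 3 values shown sit. The compounds shown leave open whether any change at this place on the shared core affects growth inhibition, and by how much.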